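This account rests on a few compounds, and the source may have more. Where it says the series, first, only, none or still open, it means among the compounds named here.

Compound 1, `COc1cc(-c2cc(/C=C/C(=O)c3ccc(Cl)c(Cl)c3)[nH]n2)cc(OC)c1OC`, gives 65% in a functional assay on OVCAR-5 cells (Homo sapiens) for cytotoxicity, read by sulforhodamine B assay, with a stated time of 48 h, tested at 10 uM; a higher number here means a weaker effect of the compound at the concentration tested, a lower number a stronger effect.
Compound 2, `COc1ccc(C(=O)/C=C/c2cc(-c3cc(OC)c(OC)c(OC)c3)n[nH]2)cc1OC`, gives -93% in this assay.

Of the two measured compounds, compound 2 stands lowest, and the gap to compound 1 is given by the step of a number 158 percentage points lower from compound 1 to compound 2 (beyond the scatter), which lies beyond the scatter. Compound 3, `COc1cc(C(=O)/C=C/c2cc(-c3cc(OC)c(OC)c(OC)c3)n[nH]2)cc(OC)c1OC`, differs from compound 2 in one place: methoxy in place of hydrogen on an aromatic carbon. For the measured compounds named here, the only measured step exchanges one whole ring on the carbonyl carbon for another, which is a different kind of change from placing a methoxy where a hydrogen stood, so no measured step directly covers the move to compound 3. With nothing pointing away from compound 2, the number for compound 3 is expected to stay close to it, and the step of a number 13 percentage points higher from compound 2 to compound 3 (beyond the scatter) is expected to remain within the scatter. Compound 3 is therefore estimated at -80%, within the range -100% to -30%.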

Compound 3, a percentage reported as activity, at one concentration (the size of the read-out at that concentration, not a potency): -91%
Estimate against measurement, compound 3: 11 percentage points above; the range from low to high includes it.
By their numbers in this assay, from the lowest: compounds 2 and 3 (each within the scatter of the next); then compound 1.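

The added methoxy, on an aromatic carbon ortho to a methoxy group, goes with a number 2 percentage points higher from compound 2 to compound 3 (within the scatter) in this assay. This position therefore accepts a methoxy in place of hydrogen with no change that can be told apart from the scatter, something the earlier exchange of one whole ring for another, a number 158 percentage points lower from compound 1 to compound 2 (beyond the scatter), could not show. Nothing measured here explains why the number holds at this position.

Going by these compounds, whether this position accepts any group other than methoxy remains open, for instance a hydroxyl, an amine or a carboxylic acid. Also open, on these data alone, is whether the same lack of change would appear with a longer chain such as ethoxy, or with a methoxy added to the ring of compound 1.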